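The compounds below may be only part of what the source reports. "The series", "measured", "known", "first", "only" and "open" are said of these compounds alone.

Compound 1 `CN(C)c1ncnc2c1c(-c1cc3ccccc3o1)cn2[C@@H]1O[C@H](CO)[C@@H](O)[C@H]1O` gives > 20000 nM in a functional assay on HepG2 cells (Homo sapiens) for antiproliferative activity, read by XTT assay, with a stated time of 72 h (on this read-out lower numbers stand for stronger inhibition and higher numbers for weaker inhibition), which is a limit of the assay. Compound 2 `C#Cc1cn([C@@H]2O[C@H](CO)[C@@H](O)[C@H]2O)c2ncnc(N(C)C)c12` gives 1320 nM in this assay. Compound 3 `CNc1ncnc2c1c(-c1cc3ccccc3o1)cn2[C@@H]1O[C@H](CO)[C@@H](O)[C@H]1O` gives > 20000 nM in this assay, again a limit of the assay.

Compound 3 therefore stands at the limit of > 20000 nM in this assay, at which 2 of the 3 values shown sit, and no number can be attached to it. The step to compound 4 `C#Cc1cn([C@@H]2O[C@H](CO)[C@@H](O)[C@H]2O)c2ncnc(NC)c12` is ethynyl in place of 1-benzofuran-2-yl on an aromatic carbon. The same replacement has been measured once, from compound 1 to compound 2, where it gave an at least 15-fold lower number from compound 1 to compound 2 (1.18 log units; beyond the scatter). Among the compounds with values here, the other measured step, a step that the two limits leave unreadable from compound 1 to compound 3, shows only that both of its compounds sit at the same limit, so nothing in the data says the replacement should behave differently when compound 3 is the starting point. A large step downwards is therefore expected in this assay, of about an at least 13-fold lower number from compound 3 to compound 4 (1.12 log units; beyond the scatter). The estimate for compound 4 is 1500 nM, with a range from 400 nM to 6000 nM. This expectation rests on compound 2, which gives 1320 nM after the same change.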

Compound 4, half-maximal inhibitory concentration: > 15000 nM
Compound 4 gave a limit, no number; the forecaster's own chance of this, stated with the estimate: 10%; middle value at least 10-fold (1.00 log units) from the limit.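

In this assay, the ethynyl group on this aromatic carbon does not keep its effect when the nitrogen on the aromatic ring loses a methyl: hydrogen in place of methyl there gives an at least 11-fold higher number from compound 2 to compound 4 (1.05 log units; beyond the scatter). Within the data shown here, with 1-benzofuran-2-yl at this carbon, the same change could not be sized, so this is the first readable sign that the substitution on that nitrogen matters. Compound 4 sits at a limit of the assay: the limit of > 15000 nM in this assay, at which 1 of the 4 values shown sits.

Going by these compounds, the steps from compound 1 to compound 3 and from compound 3 to compound 4 cannot be read, so it remains open whether ethynyl offers any gain over 1-benzofuran-2-yl when the nitrogen carries one methyl. Also open, on these data alone, is how an unsubstituted amine or an ethyl group on that nitrogen, or a propynyl group on the aromatic carbon, would behave in this assay.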